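A few compounds are considered here, and "the series" means these few. Any claim that something is new, unique, unknown or untested is made for them only; others in the source may bear on it.

Measured compounds and their values:
- compound 1, `CCCCNC(=O)COc1ccc(C(=O)c2c(CCCC)oc3ccccc23)cc1`: > 50000 nM
- compound 2, `CCCCc1oc2ccccc2c1C(=O)c1ccc(OCC(=O)N2CCCC2)cc1`: 42400 nM
- compound 3, `CCCCc1oc2ccccc2c1C(=O)c1ccc(OCC(=O)N2CCCCC2)cc1`: > 50000 nM

All three share one core and differ only in the group on the amide nitrogen. In a functional assay on MCF7 cells (Homo sapiens) for antiproliferative activity, read by MTT assay, with a stated time of 24 h (on this read-out higher numbers stand for weaker inhibition and lower numbers for stronger inhibition), compound 1 returns a limit of the assay rather than a number, > 50000 nM. Compound 3 likewise returns only a limit, > 50000 nM. Compound 2 gives 42400 nM, a weak inhibition. The steps between them are therefore mostly floors: an at least 1.1-fold lower number from compound 1 to compound 2 (0.07 log units; that floor lies within the scatter) and an at least 1.1-fold higher number from compound 2 to compound 3 (0.07 log units; that floor lies within the scatter) stay within the scatter, and a step that the two limits leave unreadable from compound 1 to compound 3 cannot be read because the limit of > 50000 nM in this assay, at which 2 of the 3 values shown sit, caps both ends.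

Compound 4, `CCCCc1oc2ccccc2c1C(=O)c1ccc(OCC(=O)NCc2ccccc2)cc1`, changes the same amide nitrogen group once more: phenyl in place of propyl on a saturated chain carbon bound to an amide-type nitrogen. The three measured steps at this position all bear on it, and none of them shows movement beyond the scatter; every variant here stays weak or unmeasurable. Within the data shown here, no size of step in this assay is therefore expected from compound 1 to compound 4, and the most likely outcome is another limit. Compound 4 is expected to give about 50000 nM, within a range from 15000 nM to 150000 nM. The step this estimate implies, a number no higher from compound 1 to compound 4 (the limit leaves the size open), is expected to be flat.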

Compound 4, half-maximal inhibitory concentration: 19600 nM
Beside the measured number, compound 4's estimate is 2.6-fold (0.41 log units) above it, and the stated range covers the measured number.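

Phenyl in place of propyl on a saturated chain carbon bound to an amide-type nitrogen gives the first step at this position that clears the scatter in this assay (an at least 2.5-fold lower number from compound 1 to compound 4 (0.40 log units; beyond the scatter)). The benzylamino group also separates from both ring-closed amides, with a clear step from the piperidine amide (an at least 2.5-fold lower number from compound 3 to compound 4 (0.40 log units; beyond the scatter)) and from the pyrrolidine amide (a 2.2-fold lower number from compound 2 to compound 4 (0.34 log units; beyond the scatter)). Compound 4 is therefore the strongest of the four, so this amide nitrogen group can change the read-out, although no readable step among compounds 1, 2 and 3 had shown that.

From the compounds shown here alone, the full sizes of the steps from compounds 1 and 3 stay open because each of these steps starts from a limit rather than a number: the limit of > 50000 nM in this assay, at which 2 of the 4 values shown sit. Going by these compounds, it also remains open whether the phenyl ring itself matters or how far it sits from the amide nitrogen counts as well, a question that a phenethyl group, a pyridin-3-ylmethyl group or a cyclohexylmethyl group on the same nitrogen could help to settle.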